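The compounds below may be only part of what the source reports. "The series", "measured", "known", "first", "only" and "open" are said of these compounds alone.

Working notes on the series.

The core is that of compound 1 `CCOC(=O)c1ccc(-c2nn(C)c3ccccc23)cc1`. In a functional assay on cells (Platelet, Homo sapiens) for inhibition (on this read-out higher numbers stand for weaker inhibition and lower numbers for stronger inhibition), compound 1 gives > 10000 nM, which is a limit of the assay and not a number. Compound 2 `CCOC(=O)c1ccc(-c2nn(Cc3cccc(Cl)c3)c3ccccc23)cc1` adds to that core. In this assay compound 2 gives > 10000 nM, again a limit. Compound 3 `CCOC(=O)c1ccc(-c2nn(Cc3cccc(F)c3)c3ccccc23)cc1` is the fluoro analogue of compound 2. In this assay compound 3 gives > 10000 nM, also a limit. Compound 3 thus stands where every value of the series stands so far, as the limit of > 10000 nM in this assay, at which 3 of the 3 values shown sit, shows, and none of the three compounds can be ordered against another.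

The measured steps are a step that the two limits leave unreadable from compound 1 to compound 2, a step that the two limits leave unreadable from compound 1 to compound 3 and a step that the two limits leave unreadable from compound 2 to compound 3; each is pinned between two limits, so none has a readable size or direction.

Compound 4 `CCOC(=O)c1ccc(-c2nn(Cc3cccc(OC)c3)c3ccccc23)cc1` has not yet been measured. It differs from compound 3 as follows: methoxy in place of fluoro on an aromatic carbon. For the measured compounds named here, the step from compound 2 to compound 3 is the only one touching the same aromatic carbon, and it is unreadable, so no measured step gives a usable size for this change. Because compound 3 gives only the limit > 10000 nM, compound 4 is expected to remain near or beyond that limit, with an estimated step that the limit leaves unreadable from compound 3 to compound 4. Compound 4 is therefore estimated at 15000 nM, within a range from 5000 nM to 60000 nM.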

Compound 4, half-maximal inhibitory concentration: > 10000 nM
Compound 4: no number, only a limit; the forecaster's own chance of this, stated with the estimate: 85%; the middle value does not contradict the limit.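

In this assay, for the compounds shown here, compound 4 gives > 10000 nM, a limit and not a number, so no step from compound 1, compound 2 or compound 3 to compound 4 can be read: the limit of > 10000 nM in this assay, at which 4 of the 4 values shown sit. The compounds shown leave open how these four compounds rank and which change to the shared core would give a measurable inhibition.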